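This account rests on a few compounds, and the source may have more. Where it says the series, first, only, none or still open, it means among the compounds named here.

Of the compounds shown here, three have a number so far. Compound 1 `CNC(=O)c1c(O)c2cccnc2n(-c2ccccc2)c1=O` carries a methyl on the amide-type nitrogen; in a functional assay on the whole organism for inhibition, with Rattus norvegicus as the target, read by paw edema, at a dose of 100 mg/kg by the oral route (a lower number here means less inhibition, a higher number more inhibition at the dose given (going by the name of the read-out)), compound 1 gives 9.6%. Compound 2 `COc1ccc(NC(=O)c2c(O)c3cccnc3n(-c3ccccc3)c2=O)cc1` carries a 4-methoxyphenyl there, and in this assay compound 2 gives 0.3%. The step between them is a number 9.3 percentage points lower from compound 1 to compound 2 (within the scatter). Compound 3 `O=C(Nc1cccc(Cl)c1)c1c(O)c2cccnc2n(-c2ccccc2)c1=O` carries a 3-chlorophenyl; in this assay compound 3 gives 7.6%. Compound 3 stands second highest of the three numbers, with a number 2 percentage points lower from compound 1 to compound 3 (within the scatter) and a number 7.3 percentage points higher from compound 2 to compound 3 (within the scatter), so none of the three is set apart from the others.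

Compound 4 `O=C(Nc1cccc([N+](=O)[O-])c1)c1c(O)c2cccnc2n(-c2ccccc2)c1=O` differs from compound 3 by nitro in place of chloro on an aromatic carbon, 3-chlorophenyl to 3-nitrophenyl. Among the compounds with values here, the steps that bear on it are the two earlier changes of the group on the amide-type nitrogen, a number 2 percentage points lower from compound 1 to compound 3 (within the scatter) and a number 7.3 percentage points higher from compound 2 to compound 3 (within the scatter), both within the scatter, as is a number 9.3 percentage points lower from compound 1 to compound 2 (within the scatter). Three different groups on that nitrogen thus leave this assay about where it was, and no step beyond the scatter is expected for compound 4 either. The expected step is a number 0.6 percentage points lower from compound 3 to compound 4 (within the scatter). Compound 4 is estimated at 7%, within a range from 0% to 20%.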

Compound 4, a percentage reported as inhibition, in the whole organism at one dose (the size of the read-out at that dose, not a potency): 5.7%
Compound 4: the middle estimate sits 1.3 percentage points above what was measured, within the range that was stated.
By their numbers in this assay, from the lowest: compounds 2, 4, 3 and 1 (each within the scatter of the next).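

Nitro in place of chloro on an aromatic carbon keeps the phenyl ring on the amide-type nitrogen and changes only the group it carries, and in this assay this gives a number 1.9 percentage points lower from compound 3 to compound 4 (within the scatter). The 3-nitrophenyl group also stays within the scatter of the other groups at that nitrogen, with a number 5.4 percentage points higher from compound 2 to compound 4 (within the scatter) and a number 3.9 percentage points lower from compound 1 to compound 4 (within the scatter), so the four groups are not told apart in this assay. No independent data bear on this result.

The compounds shown leave open whether an amine or a carboxylic acid on that phenyl ring, or a longer chain in place of the methyl of compound 1, would move the read-out beyond the scatter. Also open, going by these compounds, is whether a benzyl group in place of the phenyl group that all four compounds carry on the shared core would do so.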